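Phenethyl in Place of Phenyl on a Fused Core

The compounds below may be only part of what the source reports. "The series", "measured", "known", "first", "only" and "open" are said of these compounds alone.

Of the compounds shown here, two have so far been measured in a functional assay on FM3A cells (Mus musculus) for inhibition, read by cell counting, with a stated time of 2 days; on this read-out lower numbers stand for stronger inhibition and higher numbers for weaker inhibition. Compound 1 `C=C(Br)C(=O)Nc1cccc(-c2cn3nc(-c4ccccc4)sc3n2)c1` gives 900 nM in this assay, and compound 2 `C=C(Br)C(=O)Nc1cccc(-c2cn3c(-c4ccc(Cl)cc4)csc3n2)c1` gives 1100 nM; the gap between them lies within the scatter, so the two cannot be told apart. Compound 3 `C=C(Br)C(=O)Nc1cccc(-c2cn3nc(CCc4ccccc4)sc3n2)c1` differs from compound 1 by phenethyl in place of phenyl on an aromatic carbon. For the measured compounds named here, no measured pair shows what this change does, so only a modest step is expected, in either direction or none beyond the scatter. Compound 3 is estimated at 1500 nM, within a range from 400 nM to 5000 nM. That estimate corresponds to an expected step of a 1.7-fold higher number from compound 1 to compound 3 (0.22 log units; within the scatter).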

Compound 3, half-maximal inhibitory concentration: 2600 nM
Estimate against measurement, compound 3: 1.7-fold (0.24 log units) below; measured number inside the range.
By their numbers in this assay, from the lowest: compounds 1 and 2 (each within the scatter of the next); then compound 3.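

Phenethyl in place of phenyl on this aromatic carbon weakens inhibition in this assay by a 2.9-fold higher number from compound 1 to compound 3 (0.46 log units; beyond the scatter) and this is the first change at this position that can be read beyond the scatter. The loss is modest, so the position still accepts an aromatic ring set further out from the shared core while inhibition remains in a similar range. Nothing available here gives a reason for this step. On these data alone, whether benzyl would fall between phenyl and phenethyl stays open, as does the effect of a longer chain or an amine at this carbon.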